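The compounds below may be only part of what the source reports. "The series", "measured", "known", "first", "only" and "open" are said of these compounds alone.

Measured compounds:
Compound 1, `CN(C)c1ncnc2c1ncn2C`, gives 33% in a functional assay on the whole organism for inhibition, with Rattus norvegicus as the target, in the maximal electroshock model, at a dose of 25 mg/kg by the intraperitoneal route; on this read-out lower numbers stand for less inhibition and higher numbers for more inhibition at the one dose given (going by the name of the read-out).
Compound 2, `CN(C=O)c1ncnc2c1ncn2Cc1ccccc1`, gives 0% in this assay.
Compound 3, `CN(C)c1ncnc2c1ncn2Cc1ccc(Cl)cc1`, gives 0% in this assay.

Of the compounds shown here, three share one core and have been tested in this assay. Compound 3 stands level with compound 2 at the digits shown, and together they carry the lowest of the three numbers; the two differ by nothing beyond the usual scatter. Compound 1 stands apart from compound 3 by a gap that lies beyond the scatter, its number being higher.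

The next compound, compound 4, `CN(C)c1ncnc2c1ncn2Cc1ccc(O)cc1`, is compound 3 with one change: hydroxy in place of chloro on an aromatic carbon. For the measured compounds named here, nothing among the measured compounds shows what swapping one group for another on this ring does to the read-out, so the size of the step can only be guessed. Both compounds that carry a group on this ring, compound 2 and compound 3, gave no inhibition at the dose tested, and the expected step is therefore small: the step from compound 3 to compound 4 is expected to be a number 5 percentage points higher from compound 3 to compound 4 (within the scatter), with no direction that can be trusted beyond the scatter. Compound 4 is estimated at 5%, with a range from 0% to 30%.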

Compound 4, a percentage reported as inhibition, in the whole organism at one dose (the size of the read-out at that dose, not a potency): 0%
Beside the measured number, compound 4's estimate is 5 percentage points above it; the range from low to high includes it.
By their numbers in this assay, from the lowest: compounds 2, 3 and 4 (each within the scatter of the next); then compound 1.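

In this assay, for the compounds shown here, putting hydroxy in place of chloro on an aromatic carbon para to a large group gives no change at the digits printed from compound 3 to compound 4 (within the scatter), and this is the first direct reading of a swap at this place on the ring. A hydrogen-bond donor and acceptor enter where chloro had neither, and the read-out does not move. Going by these compounds alone, the reading is limited, though: compound 3 gives 0% and compound 4 gives 0% at a single dose, which is the bottom of the scale, so a swap that weakened the underlying effect could not show up here, and only one that raised the number could have. No other measurement on these compounds offers an explanation for the result.

Still open, as far as these compounds go, is whether any other group at this place, such as an amine, a carboxylic acid or a longer chain like butoxy, can lift the number off the bottom of the scale. Also open, from the compounds shown here alone, is whether a higher dose would separate compound 3 from compound 4, as one dose gives the size of an effect and not a potency.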